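A methoxyphenyl for a cycloheptyl on the imidazole chain

The compounds below may be only part of what the source reports. "The series", "measured", "known", "first", "only" and "open" are said of these compounds alone.

Of the compounds shown here, three built on a shared core have been measured in an in vitro functional assay on cells for agonist activity at Bombesin receptor subtype-3 (Homo sapiens), read by luminescence and calcium flux; on this read-out higher numbers stand for an effect only at larger amounts of compound and lower numbers for an effect already at smaller amounts. Compound 1 `O=C(O)c1ccccc1-c1ccc(CCc2ncc(Cc3ccccc3F)[nH]2)cc1` gives 177 nM in this assay. Compound 2 `O=C(O)c1ccccc1-c1ccc(CCc2ncc(CCC3CCCCC3)[nH]2)cc1` gives 642 nM. Among the compounds with values here, compound 3 `O=C(O)c1ccccc1-c1ccc(CCc2ncc(CC3CCCCCC3)[nH]2)cc1` gives 88 nM, the lowest of the three numbers, though the gap to compound 1 is within the scatter, and only the step of a 7.3-fold lower number from compound 2 to compound 3 (0.86 log units; beyond the scatter) is beyond it.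

Compound 4 `COc1ccccc1Cc1cnc(CCc2ccc(-c3ccccc3C(=O)O)cc2)[nH]1` has not yet been measured. It differs from compound 3 in one place: 2-methoxyphenyl in place of cycloheptyl on a saturated chain carbon bound to an aromatic carbon. The measured steps that bear on this are those in which the group at the same place changes: a 2.0-fold lower number from compound 1 to compound 3 (0.30 log units; within the scatter), which is within the scatter, and a 3.6-fold higher number from compound 1 to compound 2 (0.56 log units; beyond the scatter) and a 7.3-fold lower number from compound 2 to compound 3 (0.86 log units; beyond the scatter), both beyond it. Compound 4 carries an aromatic ring at this place, as compound 1 does, and the step from compound 1 to compound 3 shows that a ring of that kind and a cycloheptyl give numbers within the scatter of one another. A step roughly back to the range of compound 1 is therefore expected for compound 4, that is a 2.0-fold higher number from compound 3 to compound 4 (0.31 log units; beyond the scatter), a small rise that may well fall within the scatter. Compound 4 is estimated to give 180 nM in this assay, with a likely range from 70 nM to 450 nM.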

Compound 4, half-maximal effective concentration: 1720 nM
For compound 4 the middle estimate is 9.6-fold (0.98 log units) below the measured one; measured number above the stated range.
By their numbers in this assay, from the lowest: compounds 3 and 1 (each within the scatter of the next); then compound 2; then compound 4.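

The change from fluoro to methoxy on the aromatic ring, with nothing else altered, gives a 9.7-fold higher number from compound 1 to compound 4 (0.99 log units; beyond the scatter) in this assay and so shows that an aromatic ring at this place does not by itself keep the number near that of compound 1: what the ring carries counts as well. Against the saturated groups the picture is the same, since 2-methoxyphenyl in place of cycloheptyl gives a 20-fold higher number from compound 3 to compound 4 (1.29 log units; beyond the scatter) as the largest step among these compounds, and 2-methoxyphenyl in place of cyclohexylmethyl gives a 2.7-fold higher number from compound 2 to compound 4 (0.43 log units; beyond the scatter) and leaves compound 4 with the highest number of the four. Nothing measured here accounts for this rise.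

The compounds shown leave open whether the rise belongs to methoxy in particular or would also come with a chloro, a methyl or a hydroxy on the same aromatic ring. They also leave open where a plain phenyl with no group on it would fall, and so whether fluoro or methoxy is the group that moves the number away from that of the bare ring.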